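Hydroxyamide series: tert-butoxy replacing cyclopropyl, microsomal clearance

The source may report more compounds than this note shows. Statements on the series, on what has been measured and on what is new or still open speak of the compounds shown alone.

Compound 1 `O=C(NCc1cc(Cl)ccc1-n1cnnn1)[C@@H]1[C@H]2C[C@H]2CN1C(=O)[C@H](O)CC1CC1` is the reference point of this note. In an ADME assay on liver for metabolic stability, with Liver microsome (Homo sapiens) as the target, read by LC-MS, using microsomes (on this read-out lower numbers stand for slow clearance and higher numbers for fast clearance), compound 1 gives < 14 mL.min-1.g-1, which is a limit of the assay rather than a measured number. Compound 2 `CC(C)(C)[C@@H](O)C(=O)N1C[S+]([O-])C[C@H]1C(=O)NCc1cc(Cl)ccc1-n1cnnn1` shares the chlorophenyl tetrazole amide part of the core with a sulfoxide-containing ring and a tert-butyl carbinol side chain. In this assay compound 2 gives < 12 mL.min-1.g-1, again a limit and not a number. Within the data shown here, both values shown therefore sit at limits, one at the limit of < 12 mL.min-1.g-1 in this assay, at which 1 of the 2 values shown sits, and the other at the limit of < 14 mL.min-1.g-1 in this assay, at which 1 of the 2 values shown sits, so compound 1 stands among the slow-clearance entries without a quantified position, and no step between measured compounds can be read from the two.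

Compound 3 `CC(C)(C)OC[C@@H](O)C(=O)N1C[C@@H]2C[C@@H]2[C@H]1C(=O)NCc1cc(Cl)ccc1-n1cnnn1` is not yet measured. It differs from compound 1 by tert-butoxy in place of cyclopropyl on a saturated chain carbon, two bonds along the chain from a carbonyl carbon and an oxygen on a saturated carbon. With both measured values at limits, no direction of change is expected beyond the scatter; compound 3 is expected to remain in the slow-clearance range, and a step that the limit leaves unreadable from compound 1 to compound 3 is estimated. Compound 3 is expected at 10 mL.min-1.g-1, within 4 mL.min-1.g-1 to 28 mL.min-1.g-1.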

Compound 3, intrinsic clearance in microsomes: 37 mL.min-1.g-1
For compound 3 the middle estimate is 3.7-fold (0.57 log units) below the measured one; the measured number lies above the stated range.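

Tert-butoxy in place of cyclopropyl on a saturated chain carbon, two bonds along the chain from a carbonyl carbon and an oxygen on a saturated carbon, gives an at least 2.6-fold higher number from compound 1 to compound 3 (0.42 log units; beyond the scatter) in this assay and so provides the only readable step among the compounds shown. This position is therefore not silent in this read-out, and the slow-clearance standing of compound 1 does not carry over to the (tert-butoxy)methyl side chain. The step gives only a lower bound on the size of the change, since the value of compound 1 is a limit: the limit of < 14 mL.min-1.g-1 in this assay, at which 1 of the 3 values shown sits.

Among these compounds, compound 2 differs from compound 1 and compound 3 in more than one place, so no step involving it can be read. Still open, as far as these compounds go, is whether the higher clearance follows the chain oxygen or the tert-butyl end, which a methoxymethyl or a neopentyl group at this position would help to separate, and whether an amine or a carboxylic acid on the same chain would keep compound 1's slow-clearance standing.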